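Aryloxypropoxy triazine series: single-point inhibition notes

A few compounds are considered here, and "the series" means these few. Any claim that something is new, unique, unknown or untested is made for them only; others in the source may bear on it.

Measured compounds:
- compound 1 `NC1=NC2(CCOCC2)N(OCCCOc2ccccc2)C(N)=N1` — "not determined" (no result reported)
- compound 2 `NC1=NC2(CCOCC2)N(OCCCOc2ccc(Cl)cc2)C(N)=N1` — "not determined" (no result reported)
- compound 3 `Cc1cc(C)cc(OCCCON2C(N)=NC(N)=NC23CCOCC3)c1` — 88.6%

The series shares one core, varied only in the aryl group at the far end of the propoxy chain. In an assay on isolated protein for inhibition of Dihydrofolate reductase (Homo sapiens), read by spectrophotometry, using NADPH, with stated times of 5 s and 6 min, tested at 50 uM (a lower number here means a weaker effect, a higher number a stronger effect of the compound at the concentration tested), compound 1 and compound 2 carry no result, so no comparison between them and compound 3 can be drawn. Among the measured compounds shown here, compound 3 therefore stands alone on the numbers: it is the only member with a reported value, and that value, 88.6%, shows a strong effect at the concentration tested.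

Compound 4 `NC1=NC2(CCOCC2)N(OCCCOc2cccc(Br)c2)C(N)=N1` is not yet measured. It differs from compound 3 in one place: 3-bromophenyl in place of 3,5-dimethylphenyl on an oxygen on a saturated carbon. For the measured compounds named here, no step between measured compounds exists to calibrate this change, so the expected step rests on the high reading of compound 3 alone and on the change being a swap of one substituted phenyl for another of similar size. The step is expected to be small, within or near the scatter, and if anything slightly downward: a number 4.6 percentage points lower from compound 3 to compound 4 (within the scatter). Compound 4 is therefore expected to give about 84% in this assay, with a range from 65% to 96%.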

Compound 4, a percentage reported as inhibition, at one concentration (the size of the read-out at that concentration, not a potency): 85.8%
Compound 4: the middle estimate sits 1.8 percentage points below what was measured; low and high end bracket the measured number.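

In this assay, the swap of 3,5-dimethylphenyl for 3-bromophenyl on an oxygen on a saturated carbon gives the first step readable at this position: a number 2.8 percentage points lower from compound 3 to compound 4 (within the scatter). The two readings cannot be told apart, so this position accepts either substituted phenyl at the concentration tested, although a single-concentration read-out gives no potency. Nothing on hand accounts for this result.

Steps involving compound 1 and compound 2 cannot be read, so the phenyl and chlorophenyl ends give no further comparison with compound 3 or compound 4. From the compounds shown here alone, it remains open whether the reading holds with an amine or a carboxylic acid on the phenyl ring, or with a longer chain in place of the propoxy chain.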